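Quinoxaline sulfones: aminophenyl regiochemistry and the bromo core

The source may report more compounds than this note shows. Statements on the series, on what has been measured and on what is new or still open speak of the compounds shown alone.

Compound 1 `Cc1ccc(S(=O)(=O)c2nc3ccccc3nc2Nc2ccc(N)cc2)cc1` gives 24600 nM in a functional assay on A549 cells (Homo sapiens) for cytotoxicity, read by MTT assay, with a stated time of 72 h; on this read-out lower numbers stand for stronger inhibition and higher numbers for weaker inhibition. Compound 2 `Cc1ccc(S(=O)(=O)c2nc3ccccc3nc2Nc2cccc(N)c2)cc1` gives 1950 nM in this assay, and compound 3 `Nc1ccc(Nc2nc3ccccc3nc2S(=O)(=O)c2ccc(Br)cc2)cc1` gives 1020 nM. The shared change 3-aminophenyl in place of 4-aminophenyl on a nitrogen on an aromatic ring made a 13-fold lower number from compound 1 to compound 2 (1.10 log units; beyond the scatter). The cores of compound 1 and compound 3 differ by bromo in place of methyl on an aromatic carbon, which made a 24-fold lower number from compound 1 to compound 3 (1.38 log units; beyond the scatter). Compound 4 `Nc1cccc(Nc2nc3ccccc3nc2S(=O)(=O)c2ccc(Br)cc2)c1` is not yet measured; it differs from compound 3 by 3-aminophenyl in place of 4-aminophenyl on a nitrogen on an aromatic ring, the same change as from compound 1 to compound 2, at the same place. The step to compound 4 is expected to be an 8.5-fold lower number from compound 3 to compound 4 (0.93 log units; beyond the scatter), somewhat smaller than the earlier one, because compound 3 already gives 1020 nM and a second large gain on its core is uncertain from a single precedent. Compound 4 is estimated at 120 nM, between 35 nM and 500 nM.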

Compound 4, half-maximal inhibitory concentration: 1120 nM
Beside the measured number, compound 4's estimate is 9.3-fold (0.97 log units) below it; the whole stated range lies below it.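

In this assay, the change from 4-aminophenyl to 3-aminophenyl gives a 1.1-fold higher number from compound 3 to compound 4 (0.04 log units; within the scatter), so the step seen with the methyl core does not carry over to the bromo core: the same change on two cores in this assay, a 13-fold lower number (1.10 log units; beyond the scatter) from compound 1 to compound 2 and a 1.1-fold higher number (0.04 log units; within the scatter) from compound 3 to compound 4, 14-fold (1.14 log units) apart, beyond the scatter of two such steps

Bromo in place of methyl likewise gives a 1.7-fold lower number from compound 2 to compound 4 (0.24 log units; within the scatter) when 3-aminophenyl is present, so that change does not carry over either: the same change on two cores in this assay, a 24-fold lower number (1.38 log units; beyond the scatter) from compound 1 to compound 3 and a 1.7-fold lower number (0.24 log units; within the scatter) from compound 2 to compound 4, 14-fold (1.14 log units) apart, beyond the scatter of two such steps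

Neither change can be treated as a fixed step here, but this rests on only four compounds and does not show why the steps differ or how either change would behave on another core.

Going by these compounds, whether chloro or methoxy in place of bromo would behave like bromo or like methyl remains open. So does whether an acetamide or a hydroxyl group in place of the amine would keep these numbers.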